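Sulfonylurea chalcones: cytotoxicity step to compound 4

This account rests on a few compounds, and the source may have more. Where it says the series, first, only, none or still open, it means among the compounds named here.

Three members of the series carry a measured value in an ADME assay on the whole organism for cytotoxicity, with Artemia salina as the target, with a stated time of 24 h; on this read-out higher numbers stand for an effect only at larger amounts of compound and lower numbers for an effect already at smaller amounts. Compound 1 `Cc1ccc(S(=O)(=O)NC(=O)Nc2ccccc2C(=O)/C=C/c2ccccc2)cc1` gives 25 ug/mL. Compound 2 `CCc1cc(/C=C/C(=O)c2ccccc2NC(=O)NS(=O)(=O)c2ccc(C)cc2)cc(OC)c1OC` gives 19.2 ug/mL. Compound 3 `Cc1ccc(S(=O)(=O)NC(=O)Nc2ccccc2C(=O)/C=C/c2ccccc2O)cc1` gives 32.3 ug/mL. On these numbers compound 2 holds the lowest value, nearest to compound 1 and furthest from compound 3, yet every step among the three lies within the scatter: a 1.3-fold lower number from compound 1 to compound 2 (0.11 log units; within the scatter), a 1.3-fold higher number from compound 1 to compound 3 (0.11 log units; within the scatter), a 1.7-fold higher number from compound 2 to compound 3 (0.23 log units; within the scatter).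

Compound 4 `Cc1ccc(S(=O)(=O)NC(=O)Nc2ccccc2C(=O)/C=C/c2ccc(Cl)cc2Cl)cc1` is not yet measured in this assay. Relative to compound 2 the change is 2,4-dichlorophenyl in place of 3-ethyl-4,5-dimethoxyphenyl on a double-bonded chain carbon bound to a double-bonded chain carbon. Among the measured compounds shown here, the steps that bear on it are the two that also exchange the aryl group on the double-bonded chain carbon, namely a 1.3-fold lower number from compound 1 to compound 2 (0.11 log units; within the scatter) and a 1.7-fold higher number from compound 2 to compound 3 (0.23 log units; within the scatter), both within the scatter. No step beyond the scatter is therefore expected from compound 2 to compound 4 in this assay, and the expected step is a 1.3-fold higher number from compound 2 to compound 4 (0.10 log units; within the scatter). Compound 4 is thus estimated at 24 ug/mL, in a range from 12 ug/mL to 48 ug/mL.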

Compound 4, concentration for half-maximal effect: 8.34 ug/mL
The estimate for compound 4 lay 2.9-fold (0.46 log units) above the measured number; the whole stated range lies above it.
By their numbers in this assay, from the lowest: compound 4; then compounds 2, 1 and 3 (each within the scatter of the next).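

Among the compounds shown here, at the aryl group on the double-bonded chain carbon, 2,4-dichlorophenyl is the first exchange to move the number in this assay beyond the scatter, with a 2.3-fold lower number from compound 2 to compound 4 (0.36 log units; beyond the scatter) and a 3.0-fold lower number from compound 1 to compound 4 (0.48 log units; beyond the scatter) and also a 3.9-fold lower number from compound 3 to compound 4 (0.59 log units; beyond the scatter) in the same direction. Phenyl, 2-hydroxyphenyl and 3-ethyl-4,5-dimethoxyphenyl had stayed within the scatter of one another, so this place does respond to the aryl group, though all three new steps are modest, and compound 4 alone holds the low end of the four. Nothing at hand bears on why 2,4-dichlorophenyl departs from the other three groups.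

From the compounds shown here alone, whether the step needs both chlorine atoms stays open. Also open, going by these compounds, is what a bromine atom, a nitro group or an amine on this aryl ring would give.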